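The compounds below may be only part of what the source reports. "The series", "measured", "known", "first", "only" and "open" are said of these compounds alone.

Compound 1 `COc1cc(-c2cc(/C=C/C(=O)c3ccc(N)cc3)[nH]n2)cc(OC)c1OC` gives 4080 nM in a functional assay on SK-MEL-28 cells (Homo sapiens) for inhibition, read by sulforhodamine B assay, with a stated time of 48 h (on this read-out lower numbers stand for stronger inhibition of growth and higher numbers for weaker inhibition of growth), the second highest of the three numbers measured. Compound 2 `COc1ccc(-c2cc(/C=C/C(=O)c3ccc(OC)c(OC)c3)[nH]n2)cc1` gives 3070 nM, within the scatter of compound 1. Compound 3 `COc1cc(-c2cc(/C=C/C(=O)c3ccc(Cl)c(Cl)c3)[nH]n2)cc(OC)c1OC` gives 66000 nM; the step of a 16-fold higher number from compound 1 to compound 3 (1.21 log units; beyond the scatter) is the only one measured, and it sits on the carbonyl carbon, not at the place changed here. Compound 4 `COc1ccc(-c2cc(/C=C/C(=O)c3ccc(N)cc3)[nH]n2)cc1OC` differs from compound 1 by hydrogen in place of methoxy on an aromatic carbon, on an aromatic carbon ortho to a methoxy group and meta to a large group. Among the compounds with values here, no measured step bears on this change; compound 2, carrying one methoxy on that ring, lies within the scatter of compound 1, so compound 4 is expected to give 4000 nM, between 1500 nM and 12000 nM, a step of a 1.0-fold lower number from compound 1 to compound 4 (0.01 log units; within the scatter) expected to stay within the scatter.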

Compound 4, concentration for total growth inhibition: 5660 nM
The estimate for compound 4 lay 1.4-fold (0.15 log units) below the measured number, and the stated range covers the measured number.
By their numbers in this assay, from the lowest: compounds 2, 1 and 4 (each within the scatter of the next); then compound 3.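

Hydrogen in place of methoxy, on an aromatic carbon ortho to a methoxy group and meta to a large group, gives a 1.4-fold higher number from compound 1 to compound 4 (0.14 log units; within the scatter), so this methoxy can be lost without a change beyond the scatter. Within the data shown here, this is the first measured step at this place; the earlier one sat on the carbonyl carbon. Nothing on hand explains this result.

Going by these compounds, whether ethoxy, hydroxyl or an amine at this place would also leave the number unchanged remains open. So does whether the same swap behaves alike with 3,4-dichlorophenyl on the carbonyl carbon.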